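Swapping acetyl for methylsulfonyl on a pyrazole nitrogen

The source may report more compounds than this note shows. Statements on the series, on what has been measured and on what is new or still open speak of the compounds shown alone.

Four compounds share a core that carries a urea on one side and an amide-linked phenyl ring bearing a pyrazole on the other. Compound 1 `CNC(=O)N1CCCc2ccc(NC(=O)c3cccc(-c4cnn(S(C)(=O)=O)c4)c3)cc21` and compound 2 `CNC(=O)N1CCCc2ccc(NC(=O)c3cccc(-c4cnn(C(C)=O)c4)c3)cc21` differ only at the pyrazole nitrogen, (acetyl in place of methylsulfonyl on an aromatic nitrogen). In a functional assay on MV4-11 cells (Homo sapiens) for antiproliferative activity, with a stated time of 6 days, tested at 1.56 uM (on this read-out higher numbers stand for a stronger effect at the one concentration tested and lower numbers for a weaker effect), compound 1 gives 1.6%, while compound 2 gives 33.6%, so the change brought a number 32 percentage points higher from compound 1 to compound 2 (beyond the scatter). Compound 3 `CNC(=O)N1CCCc2ccc(NC(=O)c3ccc(-c4cnn(S(C)(=O)=O)c4)cc3)cc21` is built from the same atoms as compound 1 joined differently; how the two cores differ is not broken down here. In this assay compound 3 gives 4.5%, which sits within the scatter of the value of compound 1. Compound 4 `CNC(=O)N1CCCc2ccc(NC(=O)c3ccc(-c4cnn(C(C)=O)c4)cc3)cc21` stands to compound 3 as compound 2 stands to compound 1, (acetyl in place of methylsulfonyl on an aromatic nitrogen), and the surroundings of the change read the same way, so this is the same change. Going by the values given here, on the core of compound 3 a step of about a number 25.5 percentage points higher from compound 3 to compound 4 (beyond the scatter) is expected, resting on the single earlier step of a number 32 percentage points higher from compound 1 to compound 2 (beyond the scatter) and on the starting point of compound 3 at 4.5%. Compound 4 is therefore estimated at 30%, with a plausible range from 10% to 50%.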

Compound 4, a percentage reported as inhibition, at one concentration (the size of the read-out at that concentration, not a potency): 23.9%
Compound 4: the middle estimate sits 6.1 percentage points above what was measured; low and high end bracket the measured number.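

On the core of compound 3, acetyl in place of methylsulfonyl on the pyrazole nitrogen again raises the read-out in this assay, with a number 19.4 percentage points higher from compound 3 to compound 4 (beyond the scatter). Going by these compounds alone, the direction of the change and its size both carry over between these two cores, which are built from the same atoms joined differently: the same change on two cores in this assay, a number 32 percentage points higher (beyond the scatter) from compound 1 to compound 2 and a number 19.4 percentage points higher (beyond the scatter) from compound 3 to compound 4, 12.6 percentage points apart, within the scatter of two such steps This is only one pair of steps, each read at a single concentration, so it shows neither how the change affects potency nor whether it would carry over to a third core, and it gives no reason for the rise.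

The compounds shown leave open how other groups on the same pyrazole nitrogen would read, such as a plain methyl or a longer acyl chain like propanoyl. They also leave open whether the step would hold if the methylurea on the other side of the shared core were replaced by, for example, an ethylurea.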